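This account rests on a few compounds, and the source may have more. Where it says the series, first, only, none or still open, it means among the compounds named here.

Compound 1 `COc1ccc(CSSC=CC[S+]([O-])Cc2ccc(OC)cc2)cc1`: 2100 nM
Compound 2 `CCC[S+]([O-])C/C=C/SSC`: 28000 nM

In a functional assay on WHCO1 cells (Homo sapiens) for antiproliferative activity, read by MTT assay, with a stated time of 48 h (a higher number here means a weaker inhibitor, a lower number a stronger inhibitor), compound 1 has the lower of the two numbers, and compound 2 sits well beyond the scatter above it. Compound 3 `COc1ccc(C[S+]([O-])CC=CSSCc2ccc(F)cc2)cc1` differs from compound 1 in one place: fluoro in place of methoxy on an aromatic carbon. Within the data shown here, no measured pair here isolates this change, so its effect is unknown. It is expected to give at most a small step, likely within the scatter, from compound 1 to compound 3 in this assay, as a 1.4-fold higher number from compound 1 to compound 3 (0.15 log units; within the scatter). Compound 3 is therefore estimated at 3000 nM, within a range of 1000 nM to 9000 nM.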

Compound 3, half-maximal inhibitory concentration: 16000 nM
Estimate against measurement, compound 3: 5.3-fold (0.73 log units) below; measured number outside the range, above it.
By their numbers in this assay, from the lowest: compound 1; then compounds 3 and 2 (each within the scatter of the next).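

In this assay, replacing one of the two 4-methoxyphenyl groups of compound 1 with 4-fluorophenyl is not a neutral exchange, giving a 7.6-fold higher number from compound 1 to compound 3 (0.88 log units; beyond the scatter). This place on the aromatic ring therefore responds to what it carries, and methoxy gives the lower number of the two groups. Nothing measured alongside these values accounts for the step.

Going by these compounds, whether chlorine, a hydroxyl or a longer ether such as ethoxy would sit closer to methoxy or to fluoro remains open. So does whether the same exchange on the other 4-methoxyphenyl group would have a similar effect.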